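Adding a third methoxy to compound 2

This account rests on a few compounds, and the source may have more. Where it says the series, first, only, none or still open, it means among the compounds named here.

Compound 1 (`COc1cc(Cn2cnc3c(Cl)ncnc32)cc(OC)c1OC`) gives > 50000 nM as a limit, not a number
Compound 2 (`COc1cc(Cn2cnc3c(Cl)nc(Cl)nc32)cc(OC)c1`) gives 3800 nM as a measured number

For the measured compounds named here, in a functional assay on AGS cells (Homo sapiens) for antiproliferative activity, read by MTT assay, with a stated time of 48 h (on this read-out lower numbers stand for stronger inhibition of growth and higher numbers for weaker inhibition of growth), compound 2 holds the only actual number so far, and the one other reading is a limit. That leaves no measured scale on which to rank compound 2 more finely.

Compound 3 (`COc1cc(Cn2cnc3c(Cl)nc(Cl)nc32)cc(OC)c1OC`) differs from compound 2 in a single place (methoxy in place of hydrogen on an aromatic carbon), where methoxy stands in place of hydrogen on an aromatic carbon, ortho to two methoxy groups and para to a large group. Going by the values given here, no measured pair of compounds differs by this change alone, so its effect has to be estimated rather than read off. The expectation in this assay is therefore modest, with no step beyond the usual scatter in either direction. The expected step is a 1.1-fold higher number from compound 2 to compound 3 (0.02 log units; within the scatter) and so stays within that scatter. Among the compounds with values here, for compound 3 the estimated value is 4000 nM with an expected range from 900 nM to 18000 nM on this read-out, a wide span for a change with no measured precedent.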

Compound 3, concentration for 50% growth inhibition: 9400 nM
Compound 3: middle estimate off by 2.4-fold (0.37 log units), on the low side, and the stated range covers the measured number.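

In this assay, for the compounds shown here, this is the first measured reading of what methoxy in place of hydrogen does at this position, ortho to two methoxy groups and para to a large group: a 2.5-fold higher number from compound 2 to compound 3 (0.39 log units; beyond the scatter), so the added group goes with weaker inhibition of growth. The other step, chloro in place of hydrogen on an aromatic carbon, is an at least 5.3-fold lower number from compound 1 to compound 3 (0.72 log units; beyond the scatter), which shows that the compound with the third methoxy can still give a measured number once this chloro is present. The reading for compound 1 is a limit and not a number, so the true size of that step stays unknown: the limit of > 50000 nM in this assay, at which 1 of the 3 values shown sits.

The compounds shown leave open whether the loss at this position belongs to methoxy in particular or would also appear with a hydroxyl, a fluorine or an ethoxy group there. They also leave open whether the chloro step would keep its size with hydrogen in place of the third methoxy.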